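Swapping the Amide Aryl Group: Compound 3 to Compound 4

The source may report more compounds than this note shows. Statements on the series, on what has been measured and on what is new or still open speak of the compounds shown alone.

Three compounds sharing one core have been measured in a functional assay on A549 cells (Homo sapiens) for antiproliferative activity, read by CCK-8 assay, with a stated time of 72 h; a lower number here means a stronger inhibitor, a higher number a weaker inhibitor:

- compound 1, `Cc1ccc(C(=O)Nc2cccc(-c3oc4cc(-c5ccc(F)cc5)ccc4c(=O)c3O)c2)cc1`, gives 6910 nM
- compound 2, `O=C(Nc1cccc(-c2oc3cc(-c4ccc(F)cc4)ccc3c(=O)c2O)c1)c1ccc(F)cc1F`, gives 20500 nM
- compound 3, `O=C(Nc1cccc(-c2oc3cc(-c4ccc(F)cc4)ccc3c(=O)c2O)c1)c1ccc(Br)cc1`, gives 13500 nM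

Compound 3 sits in the middle of these three numbers, yet neither neighbour is separated from it by more than the scatter: a 2.0-fold higher number from compound 1 to compound 3 (0.29 log units; within the scatter) and a 1.5-fold lower number from compound 2 to compound 3 (0.18 log units; within the scatter). Among the measured compounds shown here, the only step beyond the scatter is a 3.0-fold higher number from compound 1 to compound 2 (0.47 log units; beyond the scatter), a modest one.

Compound 4, `Cc1cc(C(=O)Nc2cccc(-c3oc4cc(-c5ccc(F)cc5)ccc4c(=O)c3O)c2)ccc1F`, is the next variation on the amide arm. Relative to compound 3 the change is 4-fluoro-3-methylphenyl in place of 4-bromophenyl on a carbonyl carbon. The group that enters combines a fluorine, as in compound 2, with a methyl, as in compound 1, on the same ring; both of those compounds are within the scatter of compound 3 in this assay. For the measured compounds named here, no measured step bears directly on this exact group, so compound 4 is expected to stay close to compound 3, with a 1.1-fold lower number from compound 3 to compound 4 (0.05 log units; within the scatter) as the estimated step and no direction beyond the scatter. The estimate for compound 4 in this assay is 12000 nM, expected to fall between 5000 nM and 30000 nM.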

Compound 4, half-maximal inhibitory concentration: 11500 nM
The estimate for compound 4 lay 1.0-fold (0.02 log units) above the measured number, and the stated range covers the measured number.
By their numbers in this assay, from the lowest: compounds 1, 4, 3 and 2 (each within the scatter of the next, the first and the last beyond it).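

In this assay, placing 4-fluoro-3-methylphenyl on the carbonyl carbon gives a 1.2-fold lower number from compound 3 to compound 4 (0.07 log units; within the scatter), and the comparisons with the other two amide aryl groups give a 1.8-fold lower number from compound 2 to compound 4 (0.25 log units; within the scatter) and a 1.7-fold higher number from compound 1 to compound 4 (0.22 log units; within the scatter). Among the compounds shown here, compound 4 therefore shows that a ring carrying both a fluorine and a methyl stays within the scatter of all three earlier compounds, including the two separated by the only step beyond it, a 3.0-fold higher number from compound 1 to compound 2 (0.47 log units; beyond the scatter). Nothing available here accounts for any of these steps.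

All four groups on this carbonyl carbon are phenyl rings carrying only halogen or methyl substituents, so the compounds shown leave open how the number would respond to an amine, a carboxylic acid, a methoxy group or a longer alkyl chain on that ring. The rest of the shared core is identical in all four compounds, so they also leave open whether a change elsewhere would produce larger steps than those seen on the amide arm.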